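A Smaller Ring Group on the Aromatic Carbon

The source may hold more compounds than are shown below. What is called first, only, known or untested is meant among the compounds shown, and "the series" means these compounds.

compound 1 `CC(C(=O)Nc1cc(C2CC2)[nH]n1)c1ccc(N2Cc3ccccc3C2=O)cc1`: 4750 nM
compound 2 `C[C@H](C(=O)Nc1cc(C2CC2)[nH]n1)c1ccc(N2CCNC2=O)cc1`: 1270 nM
compound 3 `CC(C(=O)Nc1cc(C2CC2)[nH]n1)c1ccc(N2CCC(C(N)=O)C2=O)cc1`: 5710 nM

In a functional assay on A2780 cells (Homo sapiens) for inhibition (on this read-out higher numbers stand for weaker inhibition and lower numbers for stronger inhibition), compound 3 gives 5710 nM. That number lies within the scatter of compound 1 and stands above compound 2 by more than the scatter.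

Compound 4 `CC(C(=O)Nc1cc(C2CC2)[nH]n1)c1ccc(N2CC(=O)NC2=O)cc1` carries 2,4-dioxoimidazolidin-1-yl on that aromatic carbon instead: a group of 7 heavy atoms (3 carbon, 2 nitrogen, 2 oxygen; one five-membered non-aromatic ring with 2 hetero atoms) in place of a group of 9 heavy atoms (5 carbon, 2 nitrogen, 2 oxygen; one five-membered non-aromatic ring with 1 hetero atom), on an aromatic carbon. For the measured compounds named here, no measured pair isolates this change. Going by the values given here, the entering group most resembles the one in compound 2, which gives 1270 nM, so a modest move towards stronger inhibition is expected. The step expected in this assay is a 2.3-fold lower number from compound 3 to compound 4 (0.36 log units; beyond the scatter). Compound 4 is estimated at 2500 nM, with an expected range from 900 nM to 7000 nM.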

Compound 4, half-maximal inhibitory concentration: 4540 nM
Compound 4: middle estimate off by 1.8-fold (0.26 log units), on the low side, and the stated range covers the measured number.
By their numbers in this assay, from the lowest: compound 2; then compounds 4, 1 and 3 (each within the scatter of the next).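

In this assay, replacing the group of compound 3 with 2,4-dioxoimidazolidin-1-yl gives a 1.3-fold lower number from compound 3 to compound 4 (0.10 log units; within the scatter). For the compounds shown here, this is the only readable step at this aromatic carbon, and it shows that a smaller ring with 2 hetero atoms, carrying the same hydrogen-bond donor and acceptor counts, keeps the two compounds within the scatter of each other. No measurement shown here accounts for this result. From the compounds shown here alone, whether a piperazine ring or a simple primary amine on this aromatic carbon would fall within the scatter of compound 4 remains open.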